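Chlorine Swapped for a Hydroxyethylamino Group on the Side Chain

The compounds below may be only part of what the source reports. "The series", "measured", "known", "first", "only" and "open" are said of these compounds alone.

Three compounds share one core and have all been tested in a functional assay on L929 cells (Mus musculus) for inhibition; a lower number here means a stronger inhibitor of growth, a higher number a weaker inhibitor of growth. Compound 1 `Nc1nn2c(O)cc(-c3cc([N+](=O)[O-])c(Cl)cc3Cl)nc2c1[N+](=O)[O-]` gives > 50 ug/mL, which is a limit of the assay rather than a number. Compound 2 `Nc1nn2c(O)cc(-c3ccc(F)cc3)nc2c1[N+](=O)[O-]` gives > 50 ug/mL, again only a limit. Compound 3 `Nc1nn2c(O)cc(CCl)nc2c1[N+](=O)[O-]` gives > 50 ug/mL, also a limit. Between the last two lies a step that the two limits leave unreadable from compound 2 to compound 3, so no size can be read, and compound 3 stands at the limit of > 50 ug/mL in this assay, at which 3 of the 3 values shown sit. Compound 4 `Nc1nn2c(O)cc(CNCCO)nc2c1[N+](=O)[O-]` differs from compound 3 by (2-hydroxyethyl)amino in place of chloro on a saturated chain carbon bound to an aromatic carbon. Among the measured compounds shown here, no measured step offers a readable size, so compound 4 is expected to remain near the limit, at an estimated 60 ug/mL with a range from 20 ug/mL to 200 ug/mL. The expected step is thus a step that the limit leaves unreadable from compound 3 to compound 4, within the scatter.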

Compound 4, concentration for 50% growth inhibition: > 50 ug/mL
Compound 4 was reported as a limit; the forecaster's own chance of this, stated with the estimate: 80%; the middle value does not contradict the limit.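

The steps from compound 2 and compound 3 to compound 4 cannot be read, since all these compounds sit at a limit: the limit of > 50 ug/mL in this assay, at which 4 of the 4 values shown sit.

The compounds shown leave open how strongly any of them inhibits growth, and so which change on the shared core matters.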